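The compounds below may be only part of what the source reports. "The series", "measured", "known", "first", "only" and "open" are said of these compounds alone.

Compound 1 `CC(C)CCn1cnc2c(Nc3cccc(O)c3)nc(N[C@H]3CC[C@H](N)CC3)nc21` is measured in a functional assay on BT-474 cells (Homo sapiens) for inhibition, read by fluorescence, with a stated time of 72 h (on this read-out lower numbers stand for stronger inhibition of growth and higher numbers for weaker inhibition of growth), where compound 1 gives 14700 nM. Compound 2 `CCCCn1cnc2c(Nc3cc(OC)cc(OC)c3)nc(N[C@H]3CC[C@H](N)CC3)nc21` gives 15600 nM and compound 3 `CCCCCCn1cnc2c(Nc3cc(OC)cc(OC)c3)nc(N[C@H]3CC[C@H](N)CC3)nc21` gives 3700 nM. Among these three numbers compound 1 stands second highest: its number and that of compound 2 lie within the scatter of each other, while compound 3 gives a lower number. Going by the values given here, the one single-point step recorded in this assay is a 4.2-fold lower number from compound 2 to compound 3 (0.62 log units; beyond the scatter); it concerns the chain on the aromatic nitrogen and not the group on the other nitrogen of the shared core.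

Compound 4 `CC(C)CCn1cnc2c(Nc3ccc(O)cc3)nc(N[C@H]3CC[C@H](N)CC3)nc21` differs from compound 1 by 4-hydroxyphenyl in place of 3-hydroxyphenyl on a nitrogen on an aromatic ring. Among the compounds with values here, no measured pair in this assay shows a change of this kind, so the recorded step gives no guide to its size or direction. With nothing in the data pointing either way, no step beyond the scatter is expected from compound 1 to compound 4.

On that basis compound 4 is expected to give about 14000 nM, within a range of 5000 nM to 40000 nM, which means an expected 1.1-fold lower number from compound 1 to compound 4 (0.02 log units; within the scatter).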

Compound 4, concentration for 50% growth inhibition: 7700 nM
For compound 4 the middle estimate is 1.8-fold (0.26 log units) above the measured one; the measured number falls inside the stated range.
By their numbers in this assay, from the lowest: compound 3; then compounds 4, 1 and 2 (each within the scatter of the next, the first and the last beyond it).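

Replacing 3-hydroxyphenyl with 4-hydroxyphenyl on the nitrogen on an aromatic ring gives a 1.9-fold lower number from compound 1 to compound 4 (0.28 log units; within the scatter) in this assay and so does not separate the two compounds. Going by these compounds alone, this is the first step recorded at this position, as the earlier step from compound 2 to compound 3 concerned only the chain on the aromatic nitrogen. No supporting data accompany this result to help interpret it.

On these data alone, whether a different group on this nitrogen, such as a phenyl ring carrying an amine or a carboxylic acid in place of the hydroxyl, would give a step beyond the scatter remains open. Also open, as far as these compounds go, is whether a longer chain on the aromatic nitrogen, such as the hexyl chain of compound 3, would lower the number when paired with 4-hydroxyphenyl.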